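Swapping the amine on the shared core: compound 4

A few compounds are considered here, and "the series" means these few. Any claim that something is new, unique, unknown or untested is made for them only; others in the source may bear on it.

Compound 1 `CCCN(C)c1ncnc2[nH]cc(-c3cccc(Cl)c3)c12`: 218 nM
Compound 2 `Clc1cccc(-c2c[nH]c3ncnc(N4CCCCC4)c23)c1`: 167 nM
Compound 3 `CN(C)c1ncnc2[nH]cc(-c3cccc(Cl)c3)c12`: 349 nM

In an assay for inhibition of serine/threonine-protein kinase 3 (Homo sapiens), read by luminescence and ADP-Glo, in the presence of a further agent that is not named here (a higher number here means a weaker inhibitor, a lower number a stronger inhibitor), compound 3 gives 349 nM, the highest of the three numbers. The move to compound 4 `Clc1cccc(-c2c[nH]c3ncnc(NCC4CC4)c23)c1` is (cyclopropylmethyl)amino in place of dimethylamino on an aromatic carbon. Among the measured compounds shown here, two measured steps bear on this: a 1.6-fold higher number from compound 1 to compound 3 (0.20 log units; within the scatter) and a 2.1-fold higher number from compound 2 to compound 3 (0.32 log units; beyond the scatter). For the measured compounds named here, both point the same way, a larger amine group on that carbon going with a lower number, though only one step lies beyond the scatter. Compound 4 carries a still larger group, so a modest drop is expected: a 2.2-fold lower number from compound 3 to compound 4 (0.34 log units; beyond the scatter). Compound 4 is therefore estimated at 160 nM, with a range of 60 nM to 420 nM.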

Compound 4, half-maximal inhibitory concentration: 213 nM
Estimate against measurement, compound 4: 1.3-fold (0.12 log units) below; the measured number falls inside the stated range.
By their numbers in this assay, from the lowest: compounds 2, 4, 1 and 3 (each within the scatter of the next, the first and the last beyond it).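

Among the compounds shown here, compound 4 is the first compound here to place a hydrogen-bond donor and a three-membered ring in the amine on this aromatic carbon. In this assay, the change leaves every comparison within the scatter: a 1.6-fold lower number from compound 3 to compound 4 (0.21 log units; within the scatter), a 1.3-fold higher number from compound 2 to compound 4 (0.11 log units; within the scatter) and a 1.0-fold lower number from compound 1 to compound 4 (0.01 log units; within the scatter). This carbon therefore accepts an amine with a hydrogen on its nitrogen as well as the fully substituted amines, with no step beyond the scatter.

Still open, from the compounds shown here alone, is how a plain amino group, a morpholin-4-yl ring or a carboxylic acid on this carbon would compare. No measurement given here speaks to the reason for these steps.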